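A few compounds are considered here, and "the series" means these few. Any claim that something is new, unique, unknown or untested is made for them only; others in the source may bear on it.

In an ADME assay on THP-1 cells (Homo sapiens) for cytotoxicity, read by trypan blue exclusion, with a stated time of 24 h (a higher number here means a weaker inhibitor, a lower number a stronger inhibitor), compound 1 (`CN(C)c1ccc([Se]C#N)cc1`) gives 44700 nM and compound 2 (`N#C[Se]Cc1ccc(Br)cc1`) gives 28900 nM on the same read-out. Among the compounds with values here, these two numbers lie within the usual scatter of each other, so compound 2 stands level with compound 1, and the two compounds offer no measured single-place step to serve as a guide. Compound 3 (`CSc1ccc(C[Se]C#N)cc1`) differs from compound 2 at one place: methylsulfanyl in place of bromo on an aromatic carbon on an aromatic carbon, with methylsulfanyl in place of bromo. Within the data shown here, nothing measured so far speaks to this change, so no step beyond the scatter is expected in this assay and neither direction is favoured. The expected step of a 1.0-fold higher number from compound 2 to compound 3 (0.02 log units; within the scatter) therefore stays inside the scatter. Compound 3 is estimated at 30000 nM with an expected range from 12000 nM to 70000 nM in this measurement.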

Compound 3, half-maximal inhibitory concentration: 17000 nM
Compound 3: middle estimate off by 1.8-fold (0.25 log units), on the high side; low and high end bracket the measured number.
By their numbers in this assay, from the lowest: compounds 3, 2 and 1 (each within the scatter of the next, the first and the last beyond it).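

Compound 2 and compound 3 provide the first measured single-place step among these compounds: methylsulfanyl in place of bromo on an aromatic carbon, para to a group of 4 heavy atoms, reads in this assay as a 1.7-fold lower number from compound 2 to compound 3 (0.23 log units; within the scatter) and so stays within the scatter. Within the data shown here, compound 3 therefore stands level with compound 2, and this place accepts methylsulfanyl, of 2 heavy atoms, in place of the single bromine with no step beyond the scatter. Among these compounds, the pair gives a first reading at this position, but one step sets no trend for it.

On these data alone, it remains open whether a carboxylic acid or a methoxy group on this aromatic carbon would move the number beyond the scatter. As far as these compounds go, it is equally open whether the same exchange would read alike on the core of compound 1. Nothing measured here offers an explanation for the size of this step.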